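The compounds below may be only part of what the source reports. "The series", "measured", "known", "first", "only" and "open" are said of these compounds alone.

Measured compounds:
compound 1 `COc1cc(-c2cc(=O)c3cc(O)ccc3o2)cc(OC)c1OC`, with > 25 ug/mL in a functional assay on MCF7 cells (Homo sapiens) for cytotoxicity, read by MTT assay, with a stated time of 6 days; a lower number here means that less compound is needed, a higher number that more compound is needed for the effect
compound 2 `COc1cc(-c2cc(=O)c3ccc(O)cc3o2)cc(OC)c1OC`, with > 25 ug/mL in this assay
compound 3 `COc1ccc2oc(-c3cc(OC)c(OC)c(OC)c3)cc(=O)c2c1`, with > 25 ug/mL in this assay

Each of these three values is a limit of this assay and not a number. For compound 1 the value > 25 ug/mL is such a limit. For compound 2 the value > 25 ug/mL is likewise only a limit. For compound 3 the value > 25 ug/mL is a limit as well. All three therefore sit together at the limit of > 25 ug/mL in this assay, at which 3 of the 3 values shown sit.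

Compound 1 and compound 3 differ in one place, (methyl in place of hydrogen on an oxygen on an aromatic ring). The step between them, a step that the two limits leave unreadable from compound 1 to compound 3, cannot be read, since both ends are limits.

Compound 2 has the same atoms as compound 1 joined differently; the difference between the two cores is not broken down here. Compound 4 `COc1ccc2c(=O)cc(-c3cc(OC)c(OC)c(OC)c3)oc2c1` has not yet been measured in this assay. It differs from compound 2 by methyl in place of hydrogen on an oxygen on an aromatic ring, the same change that leads from compound 1 to compound 3, and the surroundings of the place are described in the same words in both cases.

Among the compounds with values here, because the measured step that the two limits leave unreadable from compound 1 to compound 3 is unreadable and because the limit of > 25 ug/mL in this assay, at which 3 of the 3 values shown sit, holds every value so far, the expectation for compound 4 rests on little more than the shared limit. The step from compound 2 to compound 4 is expected to be about a step that the limit leaves unreadable from compound 2 to compound 4. Compound 4 is estimated at 30 ug/mL, within a range from 10 ug/mL to 100 ug/mL, and most likely it too will be reported only as a limit in this assay.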

Compound 4, concentration for half-maximal effect: > 25 ug/mL
Compound 4 gave a limit, no number (the forecaster's own chance of this, stated with the estimate: 75%); the middle value does not contradict the limit.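

Compound 4 gives > 25 ug/mL in this assay, and this is a limit of the assay and not a number. Compound 2 also has only a limit, so the step from hydroxy to methoxy between compound 2 and compound 4 cannot be read. The compounds shown leave open how much of any of them would be needed for the effect, since every value sits at the same limit: the limit of > 25 ug/mL in this assay, at which 4 of the 4 values shown sit.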